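Swapping the Handedness of a Fluorocyclopropyl Amide

The compounds below may be only part of what the source reports. "The series", "measured", "known", "first", "only" and "open" are said of these compounds alone.

In an assay on SH-EP1 cells for agonist activity at Neuronal acetylcholine receptor; alpha4/beta2 (Homo sapiens), read by FLIPR and calcium flux (on this read-out lower numbers stand for an effect already at smaller amounts and higher numbers for an effect only at larger amounts of compound), compound 1 `CCC(=O)N1CC2CC(C1)N2` gives 5900 nM. Compound 2 `CCCC(=O)N1CC2CC(C1)N2` gives 850 nM, and compound 3 `O=C([C@H]1C[C@H]1F)N1CC2CC(C1)N2` gives 1500 nM. Among these three numbers compound 3 stands second highest: its nearest neighbour is compound 2, and the gap between them, a 1.8-fold higher number from compound 2 to compound 3 (0.25 log units; within the scatter), lies within the scatter, while the gap to compound 1, a 3.9-fold lower number from compound 1 to compound 3 (0.59 log units; beyond the scatter), lies beyond it. The remaining step, a 6.9-fold lower number from compound 1 to compound 2 (0.84 log units; beyond the scatter), shows that a longer chain on the carbonyl carbon comes with a lower number.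

Compound 4 `O=C([C@@H]1C[C@@H]1F)N1CC2CC(C1)N2` is the mirror image of compound 3 at its small ring: the two compounds have the same atoms and bonds; at least one stereo element is drawn with a configuration in one of them and without one in the other: 2 of 4 stereo elements differ; a stereocentre at a saturated ring carbon is drawn R in compound 3 and S in compound 4; a stereocentre at a saturated ring carbon is drawn R in compound 3 and S in compound 4. Nothing leaves and nothing enters. Among the compounds with values here, none of the measured steps changes a stereocentre, so no measured step bears directly on this change. Mirror-image pairs can give numbers close together or far apart, and the three measured compounds give no way to tell which case applies here. The estimate therefore starts from the value of compound 3 and carries a wide range. For compound 4 in this assay the expected step is a 1.7-fold higher number from compound 3 to compound 4 (0.22 log units; within the scatter). Compound 4 is expected to give about 2500 nM, within a range from 600 nM to 12000 nM.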

Compound 4, half-maximal effective concentration: 370 nM
Beside the measured number, compound 4's estimate is 6.8-fold (0.83 log units) above it; measured number below the stated range.
By their numbers in this assay, from the lowest: compound 4; then compounds 2 and 3 (each within the scatter of the next); then compound 1.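

Within the data shown here, compound 3 and compound 4 have the same atoms and bonds, yet the drawn handedness at the small ring is enough to move the number in this assay (in this pair, a 4.1-fold lower number from compound 3 to compound 4 (0.61 log units; beyond the scatter)), something no earlier step could show. The earlier compounds shown here suggested that 2-fluorocyclopropyl in place of propyl on the carbonyl carbon gives no readable change, but that holds only for compound 3: with the other drawn configuration there is a real gain (here, a 2.3-fold lower number from compound 2 to compound 4 (0.36 log units; beyond the scatter)), and the step in place of ethyl becomes the largest of the set (here, a 16-fold lower number from compound 1 to compound 4 (1.20 log units; beyond the scatter)), which leaves compound 4 with the lowest number of the four. How cleanly the step between the mirror-image forms can be read is limited by one fact: the fact that one of compounds 3 and 4 is drawn with a defined configuration and the other without, at the place where they differ.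

Going by these compounds, it remains open how a plain cyclopropyl or a butyl chain on the carbonyl carbon would compare with compound 4, so the part played by the fluorine itself cannot be separated from that of the ring. Also open, on these data alone, is whether the same order of compound 3 and compound 4 would hold at any other receptor.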